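Swapping chloro for methyl on the aryl enone of compound 3

The compounds below may be only part of what the source reports. "The series", "measured", "known", "first", "only" and "open" are said of these compounds alone.

Of the compounds shown here, three that share one core have been measured in a functional assay on DU-145 cells (Homo sapiens) for antiproliferative activity, read by MTT assay, with a stated time of 24 h; a higher number here means a weaker inhibitor, a lower number a stronger inhibitor. Compound 1 `COc1ccc(C(=O)/C=C/c2cc(-c3ccc(OC)c(OC)c3)n3nc(-c4ccccc4)cc3n2)cc1` gives 14600 nM. Compound 2 `COc1ccc(-c2cc(/C=C/C(=O)c3ccc(Cl)cc3)nc3cc(-c4ccccc4)nn23)cc1OC` gives 21300 nM, and compound 3 `COc1ccc(-c2cc(C(=O)/C=C/c3ccc(Cl)cc3)nc3cc(-c4ccccc4)nn23)cc1OC` gives 22400 nM. The three numbers lie close together: the step of a 1.5-fold higher number from compound 1 to compound 2 (0.16 log units; within the scatter) and the step of a 1.1-fold higher number from compound 2 to compound 3 (0.02 log units; within the scatter) are both inside the scatter, as is a 1.5-fold higher number from compound 1 to compound 3 (0.19 log units; within the scatter), so compound 3 cannot be set apart from the other two.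

Compound 4 `COc1ccc(-c2cc(C(=O)/C=C/c3ccc(C)cc3)nc3cc(-c4ccccc4)nn23)cc1OC` differs from compound 3 by methyl in place of chloro on an aromatic carbon. The nearest measured comparison is the exchange of one small group for another at the same kind of place, seen in compound 1 to compound 2, and that step stayed inside the scatter; the flip of the enone between compound 2 and compound 3 did likewise. Nothing measured here points to a shift beyond the scatter, so the step of a 1.1-fold lower number from compound 3 to compound 4 (0.05 log units; within the scatter) is expected to be small. Compound 4 is therefore estimated at 20000 nM, with a range of 9000 nM to 45000 nM.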

Compound 4, half-maximal inhibitory concentration: 19500 nM
The estimate for compound 4 lay 1.0-fold (0.01 log units) above the measured number; measured number inside the range.
By their numbers in this assay, from the lowest: compounds 1, 4, 2 and 3 (each within the scatter of the next).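

In this assay, going by these compounds alone, methyl in place of chloro on the aromatic ring of the enone gives a 1.1-fold lower number from compound 3 to compound 4 (0.06 log units; within the scatter), the first direct exchange at this position, and the number does not readably change. The other two comparisons agree: a 1.1-fold lower number from compound 2 to compound 4 (0.04 log units; within the scatter) and a 1.3-fold higher number from compound 1 to compound 4 (0.13 log units; within the scatter) also stay inside the scatter, so the four compounds still cannot be ranked. No measurement offers an explanation for this flat result.

These compounds leave open whether any group at this position can move the number beyond the scatter, since chloro and methyl are single-atom exchanges. A carboxylic acid or a dimethylamino group on the same aromatic carbon would test this with a group of a very different kind.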